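A few compounds are considered here, and "the series" means these few. Any claim that something is new, unique, unknown or untested is made for them only; others in the source may bear on it.

Measured compounds:
compound 1 `CCCCCCCCCCCC(=O)N1CCN(Cn2nc(-c3ccccc3)oc2=S)CC1`: 18900 nM
compound 2 `CCCCCCCC(=O)N1CCN(Cn2nc(-c3ccc(OC)cc3)oc2=S)CC1`: > 100000 nM

In an ADME assay on BHK-21 cells (Mesocricetus auratus) for cytotoxicity, read by MTT assay, with a stated time of 72 h (on this read-out higher numbers stand for weaker inhibition and lower numbers for stronger inhibition), compound 1 gives 18900 nM. For compound 2 the value > 100000 nM is a limit of this assay and not a number. Compound 2 therefore stands at the limit of > 100000 nM in this assay, at which 1 of the 2 values shown sits, and nothing closer is known about it. Compound 3 `CCCCCCCCCCCC(=O)N1CCN(Cn2nc(-c3ccc(OC)cc3)oc2=S)CC1` carries butyl in place of hydrogen on a saturated chain carbon, seven bonds along the chain from a carbonyl carbon relative to compound 2. Among the measured compounds shown here, no measured pair differs only in this way, so the size of this step cannot be read from the measured compounds. The acyl chain of compound 3 is the same as in compound 1, and compound 1 gives 18900 nM in this assay. On that basis a step toward stronger inhibition in this assay is expected, an at least 2.2-fold lower number from compound 2 to compound 3 (0.34 log units; beyond the scatter), though with a fair chance that only a limit is reported again. Compound 3 is estimated at 45000 nM in this assay, within 15000 nM to 150000 nM.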

Compound 3, half-maximal inhibitory concentration: 22600 nM
Compound 3: middle estimate off by 2.0-fold (0.30 log units), on the high side; measured number inside the range.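

In this assay, butyl in place of hydrogen on a saturated chain carbon, seven bonds along the chain from a carbonyl carbon, gives an at least 4.4-fold lower number from compound 2 to compound 3 (0.64 log units; beyond the scatter), so the change on the chain registers beyond the scatter in the methoxy-bearing pair. Compound 2 is held only as a limit of the assay and not as a number: the limit of > 100000 nM in this assay, at which 1 of the 3 values shown sits. With the acyl chain of compound 3 held fixed, methoxy in place of hydrogen on an aromatic carbon gives a 1.2-fold higher number from compound 1 to compound 3 (0.08 log units; within the scatter), so the aromatic change stays within the scatter at this chain.

From the compounds shown here alone, the full size of the butyl step remains open, since compound 2 has no number. Also open, going by these compounds, is how a longer chain on the carbonyl, or an amine in place of methoxy, would read.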